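Swapping thiophen-2-yl for thiophen-3-yl in a cell assay

This account rests on a few compounds, and the source may have more. Where it says the series, first, only, none or still open, it means among the compounds named here.

Two related compounds have been measured so far in a functional assay on CCRF-CEM cells (Homo sapiens) for cytotoxicity, read by XTT assay, with a stated time of 3 days; on this read-out higher numbers stand for weaker inhibition and lower numbers for stronger inhibition. There, compound 1 (`OC[C@H]1O[C@@H](n2cc(F)c3c(-c4ccsc4)ncnc32)[C@H](O)[C@@H]1O`) gives 560 nM, and compound 2 (`OC[C@H]1O[C@@H](n2cc(Cl)c3c(-c4cccs4)ncnc32)[C@H](O)[C@@H]1O`) gives 2700 nM. Compound 2 therefore has the higher of the two numbers, which means the weaker inhibition, and the gap between them lies beyond the usual scatter of repeated measurements.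

The next compound, compound 3 (`OC[C@H]1O[C@@H](n2cc(Cl)c3c(-c4ccsc4)ncnc32)[C@H](O)[C@@H]1O`), has the same atoms as compound 2, joined differently: thiophen-3-yl in place of thiophen-2-yl on an aromatic carbon. In words, thiophen-3-yl takes the place of thiophen-2-yl on an aromatic carbon. Within the data shown here, no measured pair shows this change alone, so any forecast rests on thin evidence. Among the measured compounds shown here, the one hint is that compound 1, which also carries thiophen-3-yl, gives 560 nM, although it is not otherwise identical to compound 3. A moderate move toward stronger inhibition is therefore expected, with the estimated change being a 2.5-fold lower number from compound 2 to compound 3 (0.39 log units; beyond the scatter). For compound 3, the expected value is 1100 nM, with an estimated range from 350 nM to 3500 nM.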

Compound 3, half-maximal inhibitory concentration: 1000 nM
For compound 3 the middle estimate is 1.1-fold (0.04 log units) above the measured one, and the stated range covers the measured number.
By their numbers in this assay, from the lowest: compounds 1 and 3 (each within the scatter of the next); then compound 2.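

With the chloro group held fixed, the two compounds differ only in how the thiophene ring is joined to an aromatic carbon of the shared core. In this assay, thiophen-3-yl in place of thiophen-2-yl gives a 2.7-fold lower number from compound 2 to compound 3 (0.43 log units; beyond the scatter), a modest step showing that this carbon is sensitive to the attachment point of the ring, even with the same atoms present. With thiophen-3-yl held fixed, chloro in place of fluoro gives a 1.8-fold higher number from compound 1 to compound 3 (0.25 log units; within the scatter), so this halogen change cannot be told apart from ordinary assay variation, and the thiophene change is the only one of the two with a readable effect. No available measurement explains why the attachment point of the ring matters here.

Among these compounds, it remains open whether the same thiophene swap would give a similar step with fluoro in place of chloro, since only one such comparison can be read so far. Going by these compounds, it is also open how a phenyl or furan-3-yl ring, or an amine, would compare with thiophen-3-yl on this carbon.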